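Swapping One Fluorinated Group on Compound 3

A few compounds are considered here, and "the series" means these few. Any claim that something is new, unique, unknown or untested is made for them only; others in the source may bear on it.

Three related compounds have been measured so far, all in a functional assay on LNCaP cells (Homo sapiens) for antiproliferative activity, read by propidium iodide staining, with a stated time of 96 h; on this read-out higher numbers stand for weaker inhibition and lower numbers for stronger inhibition. In this test, compound 1 (`CC(O)(COc1ccc(S(F)(F)(F)(F)F)cc1)C(=O)Nc1ccc([N+](=O)[O-])cc1C(F)(F)F`) gives 14800 nM, and compound 2 (`CC(O)(COc1cccc(S(F)(F)(F)(F)F)c1)C(=O)Nc1ccc([N+](=O)[O-])cc1C(F)(F)F`) gives 12100 nM. Compound 3 (`CC(O)(CS(=O)(=O)c1ccc(S(F)(F)(F)(F)F)cc1)C(=O)Nc1cccc(S(F)(F)(F)(F)F)c1`) gives 11700 nM, which places it level with the other two, since its value lies within the usual scatter of both.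

The next compound to be tested is compound 4 (`CC(O)(CS(=O)(=O)c1ccc(OC(F)(F)F)cc1)C(=O)Nc1cccc(S(F)(F)(F)(F)F)c1`). It differs from compound 3 in a single place: a group of 5 heavy atoms (1 carbon, 1 oxygen, 3 fluorine; no ring) in place of a group of 6 heavy atoms (5 fluorine, 1 sulfur; no ring), on an aromatic carbon. The incoming trifluoromethoxy group stands on an aromatic carbon of a six-membered aromatic ring of carbon only, para to a large group, where the group of 6 heavy atoms stood before.

Going by the values given here, no measured pair of compounds differs in just one place, so the data give no direct guide to the effect of this swap. The only support is indirect: the three compounds differ from one another in structure, yet their values stay within the scatter. A step beyond the scatter in this assay is therefore not expected, and the estimate means a 1.0-fold higher number from compound 3 to compound 4 (0.01 log units; within the scatter). For compound 4 the expected value is 12000 nM, with an estimated range from 5500 nM to 26000 nM.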

Compound 4, half-maximal inhibitory concentration: 10700 nM
Compound 4: the middle estimate sits 1.1-fold (0.05 log units) above what was measured, within the range that was stated.
By their numbers in this assay, from the lowest: compounds 4, 3, 2 and 1 (each within the scatter of the next).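

Going by these compounds alone, this is the first pair that differs in only one place, so the position can now be read directly. In this assay the trifluoromethoxy group, in place of the group of 6 heavy atoms (5 fluorine, 1 sulfur), gives a 1.1-fold lower number from compound 3 to compound 4 (0.04 log units; within the scatter) and leaves the two compounds level, so this aromatic carbon, para to a large group, accepts this exchange with no step beyond the usual scatter, even though the incoming group counts 1 hydrogen-bond acceptor and the outgoing group 0. Nothing available explains why the two groups read alike in this test.

Both groups are rich in fluorine, so a single swap between them shows only that these two are interchangeable here and does not show how far that tolerance reaches, for instance to an amine, a carboxylic acid or a plain hydrogen at the same carbon. The group of 6 heavy atoms on the other aromatic ring stays the same in both compounds, so what an exchange at that ring would do remains an open question.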